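This account rests on a few compounds, and the source may have more. Where it says the series, first, only, none or still open, it means among the compounds named here.

Measured compounds:
- compound 1, `CC(=O)Nc1nc(-c2cccc(NS(=O)(=O)c3ccc(Br)cc3)c2)cs1`: "not active" (no number reported)
- compound 2, `CC(=O)Nc1nc(-c2cccc(NS(=O)(=O)c3cccc(Br)c3)c2)cs1`: "not active" (no number reported)
- compound 3, `CCCCCCC#Cc1cccc(S(=O)(=O)Nc2cccc(-c3csc(NC(C)=O)n3)c2)c1`: 56.9%

All three share one core and were tested in a functional assay on A-375 cells (Homo sapiens) for antiproliferative activity, read by trypan blue exclusion, with a stated time of 48 h, tested at 1 uM; a higher number here means a weaker effect of the compound at the concentration tested, a lower number a stronger effect. For compound 1 the result is reported only as "not active" (no number reported), and for compound 2 likewise only as "not active" (no number reported); neither carries a number. Going by the values given here, compound 3 is therefore the only member of the set with a number, 56.9%, and it stands alone as the compound showing a measurable effect at the concentration tested. Among the compounds with values here, no step between two measured compounds that differ in a single place is available, so nothing yet says how much any one change moves the read-out.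

Compound 4, `CC(=O)Nc1nc(-c2cccc(NS(=O)(=O)c3cccc(C#CCO)c3)c2)cs1`, is the next compound to be measured. Its difference from compound 3 is hydroxy in place of pentyl on a saturated chain carbon bound to a triple-bonded carbon. The long chain of compound 3 is thus shortened and capped with a hydroxy group. Neither compound 1 nor compound 2 carries such a chain. Because compound 2 returns "not active" (no number reported) and compound 1 returns "not active" (no number reported), a step toward a weaker effect, and so a higher number, beyond the usual scatter is expected from compound 3 to compound 4, a number 28.1 percentage points higher from compound 3 to compound 4 (beyond the scatter). Compound 4 is accordingly estimated at 85%, within a range from 62% to 100%.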

Compound 4, a percentage reported as activity, at one concentration (the size of the read-out at that concentration, not a potency): 85.4%
Compound 4: the middle estimate sits 0.4 percentage points below what was measured, and the stated range covers the measured number.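

Going by these compounds alone, putting hydroxy in place of pentyl on a saturated chain carbon bound to a triple-bonded carbon gives a number 28.5 percentage points higher from compound 3 to compound 4 (beyond the scatter) in this assay and is the first change in this set whose size can be read as a number. It shows that the outer end of this chain is not a silent part of the molecule: with everything else held the same, going from the oct-1-yn-1-yl group to the 3-hydroxyprop-1-yn-1-yl group leaves a clearly weaker effect at the concentration tested. No measurement shown here explains why the read-out moves in this way.

This single step changes two things at once, the length of the chain and the hydroxy group at its end, so the compounds shown cannot separate the share of each. A plain propyl or butyl group at this place would help to pull the two apart, while an amine or a carboxylic acid in place of the hydroxy, or a longer chain than hexyl, would show how far the trend holds in either direction.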